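The source may report more compounds than this note shows. Statements on the series, on what has been measured and on what is new or still open speak of the compounds shown alone.

Within the data shown here, in a functional assay on HaCaT cells (Homo sapiens) for inhibition, read by sulforhodamine B assay, with a stated time of 48 h (a lower number here means a stronger inhibitor of growth, a higher number a weaker inhibitor of growth), compound 1 (`CC1(/C=C/c2ccccc2)C=CC(=O)O1`) gives 119000 nM and stands at the upper end of the three numbers so far. Compound 3 (`CC1(/C=C/c2cccc(O)c2)C=CC(=O)O1`) gives 88100 nM and shares that upper end, while compound 2 (`CC1(/C=C/c2ccccc2C(F)(F)F)C=CC(=O)O1`) gives 12700 nM and lies clearly lower.

Compound 4 (`CC1(/C=C/c2ccc(O)cc2)C=CC(=O)O1`) has not yet been measured. It departs from compound 1 by a single change (hydroxy in place of hydrogen on an aromatic carbon): hydroxy in place of hydrogen on an aromatic carbon, para to a group of 9 heavy atoms.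

Among the measured compounds shown here, two measured steps bear on this change. The closer one also brings in hydroxy in place of hydrogen on an aromatic carbon (a 1.4-fold lower number from compound 1 to compound 3 (0.13 log units; within the scatter)) and stays within the scatter. The other brings in trifluoromethyl instead (a 9.4-fold lower number from compound 1 to compound 2 (0.97 log units; beyond the scatter)) and is larger, but it involves a different group and so says less about compound 4. For the measured compounds named here, no measured compound carries hydroxy at the place it takes in compound 4, so the guidance is only loose. No step beyond the scatter is therefore expected in this assay, and neither direction is clearly favoured. The estimated change is a 1.3-fold lower number from compound 1 to compound 4 (0.12 log units; within the scatter) as the expected outcome. Compound 4 is estimated at 90000 nM with an expected range from 35000 nM to 180000 nM in this read-out.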

Compound 4, concentration for total growth inhibition: 81200 nM
Beside the measured number, compound 4's estimate is 1.1-fold (0.04 log units) above it; the measured number falls inside the stated range.
By their numbers in this assay, from the lowest: compound 2; then compounds 4, 3 and 1 (each within the scatter of the next).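

In this assay the step at this place reads a 1.5-fold lower number from compound 1 to compound 4 (0.17 log units; within the scatter) and so shows that hydroxy in place of hydrogen on an aromatic carbon, para to a group of 9 heavy atoms, leaves the number within the scatter of the unsubstituted compound. Hydroxy stands at another place in compound 3, which gives 88100 nM and lies within the scatter of compound 4, so neither of the two places shown separates hydroxy from hydrogen or one hydroxy compound from the other. Of the changes shown, only trifluoromethyl in compound 2 gives a step beyond the scatter, and nothing available explains the difference between these groups or the small size of the hydroxy step.

The compounds shown leave open whether trifluoromethyl would give a step of similar size at the place hydroxy takes in compound 4. They also leave open whether a methoxy group, an amine or a carboxylic acid at that same place would stay within the scatter of compound 1, as hydroxy does.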